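Series notes: methyl in place of chloro on the phenyl

The source may hold more compounds than are shown below. What is called first, only, known or untested is meant among the compounds shown, and "the series" means these compounds.

Compound 1 `O=C1CS/C(=N\c2csc(-c3ccc(Cl)cc3)c2)N1` carries a hydrogen on the amide-type nitrogen of the ring; in a functional assay on MCF7 cells (Homo sapiens) for cytotoxicity, read by MTT assay, with a stated time of 72 h (on this read-out lower numbers stand for stronger inhibition and higher numbers for weaker inhibition), compound 1 gives only the assay limit > 50000 nM. Compound 2 `COc1cccc(N2C(=O)CS/C2=N\c2csc(-c3ccc(Cl)cc3)c2)c1` bears a 3-methoxyphenyl there, and compound 2 likewise returns the limit > 50000 nM. Compound 3 `O=C1CS/C(=N\c2csc(-c3ccc(Cl)cc3)c2)N1c1ccc(Cl)cc1` carries a 4-chlorophenyl, and compound 3 too sits at the limit > 50000 nM. For the measured compounds named here, the steps a step that the two limits leave unreadable from compound 1 to compound 2, a step that the two limits leave unreadable from compound 1 to compound 3 and a step that the two limits leave unreadable from compound 2 to compound 3 therefore have no readable size, and the limit of > 50000 nM in this assay, at which 3 of the 3 values shown sit, covers every value so far. Compound 4 `Cc1ccc(N2C(=O)CS/C2=N\c2csc(-c3ccc(Cl)cc3)c2)cc1` differs from compound 3 by methyl in place of chloro on an aromatic carbon. Going by the values given here, no measured step bears on this change, and no aryl replacement so far has moved the read-out off its limit. Compound 4 is expected at 60000 nM (range 20000 nM to 200000 nM), most likely again only a limit. For compound 4 this means an expected step that the limit leaves unreadable from compound 3 to compound 4 of no size beyond the scatter.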

Compound 4, half-maximal inhibitory concentration: > 50000 nM
Compound 4: a limit, no number; the forecaster's own chance of this, stated with the estimate: 80%; the middle value lies beyond the limit too.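

Compound 4 also gives only a limit, so its steps from compound 1, compound 2 and compound 3 cannot be read: the limit of > 50000 nM in this assay, at which 4 of the 4 values shown sit.

In this assay, as far as these compounds go, it stays open whether any group on the amide-type nitrogen of the shared core gives a readable value.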